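Methyl for oxan-4-yl on an aromatic nitrogen

This account rests on a few compounds, and the source may have more. Where it says the series, first, only, none or still open, it means among the compounds named here.

Measured so far in a physicochemical assay for solubility, in phosphate buffer, at pH 7.4 (on this read-out higher numbers stand for higher solubility and lower numbers for lower solubility), for three compounds
- compound 1 `CC(C)n1cc(-c2ccnc3[nH]c(C4CCN(Cc5cccs5)CC4)cc23)ccc1=O` gives 25000 nM
- compound 2 `CN(C)C(=O)CN1CCC(c2cc3c(-c4ccc(=O)n(C5CCOCC5)c4)ccnc3[nH]2)CC1` gives 840000 nM
- compound 3 `COc1cc(F)ccc1-c1ccnc2[nH]c(C3CCOCC3)cc12` gives 97000 nM

Compound 2 at 840000 nM stands highest of the three. Compound 3 at 97000 nM is its nearest neighbour and compound 1 at 25000 nM its furthest, and both lie lower by more than the usual scatter.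

The next compound to be read is compound 4 `CN(C)C(=O)CN1CCC(c2cc3c(-c4ccc(=O)n(C)c4)ccnc3[nH]2)CC1` which differs from compound 2 in one place. It carries methyl in place of oxan-4-yl on an aromatic nitrogen and the rest of the structure is unchanged.

Among the compounds with values here, no two measured compounds differ in one place only, so no measured step speaks to this change. Three values on different structures give no firm ground for a direction, and the working expectation in this assay is therefore no shift beyond the scatter. The expected change is a 1.1-fold lower number from compound 2 to compound 4 (0.02 log units; within the scatter) and it is expected to stay within the scatter. Compound 4 is estimated at 800000 nM with an expected range of 300000 nM to 2000000 nM given the thin evidence.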

Compound 4, solubility: > 1000000 nM
Compound 4 was reported as a limit; the forecaster's own chance of this, stated with the estimate: 15%; middle value at least 1.2-fold (0.09 log units) away from the limit.
By their numbers in this assay, from the lowest: compound 1; then compound 3; then compound 2. At a limit, above all of these: compound 4.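

In this assay, the step on the aromatic nitrogen, methyl in place of oxan-4-yl, reads as an at least 1.1-fold higher number from compound 2 to compound 4 (0.07 log units; that floor lies within the scatter). Compound 4 gives > 1000000 nM, which is a limit of this assay and not a number. This is the first one-place comparison in the series, and it shows that exchanging oxan-4-yl, with its six-membered non-aromatic ring, for methyl at this position brings no lower number, while how much higher the number lies cannot be read: the limit of > 1000000 nM in this assay, at which 1 of the 4 values shown sits.

From the compounds shown here alone, whether the true size of this step lies beyond the scatter stays open, as only its floor is available and that floor lies within the scatter. Also open, going by these compounds, is how other groups on this aromatic nitrogen would read, such as an ethyl group, a longer chain ending in an amine or a chain ending in a carboxylic acid, and whether methyl in place of oxan-4-yl gives the same direction when the rest of the structure differs from that of compound 2.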